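Swapping fluoro for methyl: 4-fluorophenyl to 4-methylphenyl

The source may report more compounds than this note shows. Statements on the series, on what has been measured and on what is new or still open speak of the compounds shown alone.

In a functional assay on HeLa cells (Homo sapiens) for antiproliferative activity, read by cell counting, with a stated time of 2 days (a lower number here means a stronger inhibitor, a higher number a weaker inhibitor), compound 2 `Nc1nc(Nc2ccc(F)cc2)sc1C(=O)c1ccccc1` gives > 10000 nM. That value is a limit of the assay and not a number. Compound 3 `Cc1ccc(Nc2nc(N)c(C(=O)c3ccccc3)s2)cc1` differs from it in one place: methyl in place of fluoro on an aromatic carbon, with methyl in place of fluoro on an aromatic carbon, para to a large group. Within the data shown here, only one measured step bears on this place. Compound 1 `COc1ccc(Nc2nc(N)c(C(=O)c3ccccc3)s2)cc1`, which carries methoxy there, gives 230 nM. Fluoro in place of methoxy produced an at least 43-fold higher number from compound 1 to compound 2 (1.63 log units; beyond the scatter), a large step beyond the scatter. Among the measured compounds shown here, no measured compound carries methyl at this place, so the size of the coming step is uncertain. From the reach shown by compound 1 at 230 nM, a sizeable move towards a stronger inhibitor is expected, stopping short of that value. The expected change in this assay is an at least 6.6-fold lower number from compound 2 to compound 3 (0.82 log units; beyond the scatter). For compound 3 the estimate is 1500 nM, with an expected range of 300 nM to 8000 nM.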

Compound 3, half-maximal inhibitory concentration: 900 nM
The estimate for compound 3 lay 1.7-fold (0.22 log units) above the measured number, and the stated range covers the measured number.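

Among these compounds, with methyl in place of fluoro, this assay shows an at least 11-fold lower number from compound 2 to compound 3 (1.04 log units; beyond the scatter), so methoxy is not the only group at this place that gives a measured number. Compound 2 sits at a limit of the assay and not at a number, and the step from it is therefore only a bound: the limit of > 10000 nM in this assay, at which 1 of the 3 values shown sits. Methyl does not match methoxy, however, with a 3.9-fold higher number from compound 1 to compound 3 (0.59 log units; beyond the scatter), which places the groups in the order methoxy, methyl, fluoro, from stronger to weaker inhibitor.

Going by these compounds, whether an amine, a hydroxyl or a longer chain such as ethyl at this place would equal or pass methoxy remains open. So does whether chloro would follow fluoro or methyl, since these compounds give no rule beyond themselves.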